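This account rests on a few compounds, and the source may have more. Where it says the series, first, only, none or still open, it means among the compounds named here.

Working notes on a small set of neprilysin inhibitors built around two related bicyclic lactam cores.

Compound 1 `O=C(O)CN1C(=O)[C@@H](NC(=O)[C@@H](CS)Cc2ccccc2)CCc2ccccc21` gives 2.1 nM in an assay on isolated protein for inhibition of Neprilysin (Homo sapiens); a higher number here means a weaker inhibitor, a lower number a stronger inhibitor. Compound 3 `O=C(O)CCN1C(=O)[C@@H](NC(=O)[C@@H](CS)Cc2ccccc2)CCc2ccccc21` carries the same core and differs from compound 1 only in the acid-bearing chain on the ring nitrogen; in this assay compound 3 gives 1.7 nM. The change is carboxymethyl in place of carboxy on a saturated chain carbon bound to an amide-type nitrogen in a ring and the step it produced is a 1.2-fold lower number from compound 1 to compound 3 (0.09 log units; within the scatter), which is within the scatter of the assay, so the two values are read as equivalent.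

Compound 2 `O=C(O)CN1C(=O)[C@@H](NC(=O)[C@@H](S)Cc2ccccc2)COc2ccccc21` is built on the second core; in this assay compound 2 gives 3.1 nM. Its values and those of compounds 1 and 3 all lie within the scatter of one another, so no order among the three is claimed. The difference between the two cores is not broken down here.

Compound 4 `O=C(O)CCN1C(=O)[C@@H](NC(=O)[C@@H](S)Cc2ccccc2)COc2ccccc21` has not yet been measured in this assay. It stands to compound 2 as compound 3 stands to compound 1: the change is carboxymethyl in place of carboxy on a saturated chain carbon bound to an amide-type nitrogen in a ring, at the same place as before, so it is the same change. On that single precedent, the step of a 1.2-fold lower number from compound 1 to compound 3 (0.09 log units; within the scatter), a step of about a 1.2-fold lower number from compound 2 to compound 4 (0.08 log units; within the scatter) is expected from compound 2 to compound 4. The estimate for compound 4 in this assay is therefore 2.6 nM, with a plausible range from 1 nM to 7 nM, resting on the value of compound 2, 3.1 nM, and on the near-flat step seen between compounds 1 and 3.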

Compound 4, half-maximal inhibitory concentration: 1.2 nM
Estimate against measurement, compound 4: 2.2-fold (0.34 log units) above; low and high end bracket the measured number.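

In this assay, carboxymethyl in place of carboxy on a saturated chain carbon bound to an amide-type nitrogen in a ring gives a 2.6-fold lower number from compound 2 to compound 4 (0.41 log units; beyond the scatter), a step that on its own lies beyond the scatter, though only modestly. Set beside the earlier step on the other core, the two do not separate: the same change on two cores in this assay, a 1.2-fold lower number (0.09 log units; within the scatter) from compound 1 to compound 3 and a 2.6-fold lower number (0.41 log units; beyond the scatter) from compound 2 to compound 4, 2.1-fold (0.32 log units) apart, within the scatter of two such steps. The change can therefore be carried from one core to the other in this assay without the two steps parting beyond the scatter, but two pairs do not show that it has a larger effect on one core, and they do not establish a rule for the series, since the pairs themselves differ from each other in more than one place.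

What the compounds shown leave open is whether the trend continues to a longer chain, such as 3-carboxypropyl, at the same place, or whether an amine or an ester could stand in for the carboxylic acid there. Also open, as far as these compounds go, is whether a carboxylic acid could take the place of the sulfur-bearing group on either core.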